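This account rests on a few compounds, and the source may have more. Where it says the series, first, only, none or still open, it means among the compounds named here.

- Compound 1 (`COc1cc(OC)c2c(=O)c(OCCCCN3CCCC3)c(-c3cc(OC)c(OC)c(OC)c3)oc2c1`) reads 26800 nM
- Compound 2 (`COc1cc(OC)c2c(=O)c(OCC(=O)N/N=C/c3ccc(C)cc3)c(-c3cc(OC)c(OC)c(OC)c3)oc2c1`) reads 10100 nM
- Compound 3 (`COc1cc(OC)c2c(=O)c(OCCCCN3CCCCC3)c(-c3cc(OC)c(OC)c(OC)c3)oc2c1`) reads 6080 nM

These numbers come from a functional assay on SGC-7901 cells (Homo sapiens) for cytotoxicity, read by MTT assay, with a stated time of 38 h (on this read-out higher numbers stand for weaker inhibition and lower numbers for stronger inhibition), and compound 2 (10100 nM) holds the second highest of the three. Its nearest neighbour lies within the scatter (a 1.7-fold lower number from compound 2 to compound 3 (0.22 log units; within the scatter)) while the furthest lies beyond it (a 2.7-fold lower number from compound 1 to compound 2 (0.42 log units; beyond the scatter)) by a modest margin.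

Compound 4 (`COc1cc(OC)c2c(=O)c(OCCCCN3CCN(C)CC3)c(-c3cc(OC)c(OC)c(OC)c3)oc2c1`) has not been measured. It replaces the side group of compound 2 with 3-(4-methylpiperazin-1-yl)propyl (a group of 10 heavy atoms (8 carbon, 2 nitrogen; one six-membered non-aromatic ring with 2 hetero atoms) in place of a group of 12 heavy atoms (9 carbon, 2 nitrogen, 1 oxygen; one six-membered aromatic ring of carbon only), on a saturated chain carbon bound to an oxygen on an aromatic ring) on a saturated chain carbon bound to an oxygen on an aromatic ring.

The closest guide is a swap of the saturated ring alone (a 4.4-fold lower number from compound 1 to compound 3 (0.64 log units; beyond the scatter)) which was modest but beyond the scatter. The ring of compound 4 matches neither of those two rings, and the two steps from compound 2 to its saturated-ring relatives shown above disagree in size. No step beyond the scatter is therefore expected (a 1.2-fold higher number from compound 2 to compound 4 (0.07 log units; within the scatter)) though the uncertainty is wide.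

For compound 4 the expected value is 12000 nM with an estimated range from 4000 nM to 30000 nM in this test.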

Compound 4, half-maximal inhibitory concentration: 6950 nM
Compound 4: middle estimate off by 1.7-fold (0.24 log units), on the high side, within the range that was stated.
By their numbers in this assay, from the lowest: compounds 3, 4 and 2 (each within the scatter of the next); then compound 1.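

In this assay, 4-methylpiperazin-1-yl and piperidin-1-yl cannot be told apart at this place, four bonds along the chain from an oxygen on an aromatic ring (a 1.1-fold higher number from compound 3 to compound 4 (0.06 log units; within the scatter)), and the much different side group of compound 2, with its six-membered aromatic ring of carbon only, cannot be told apart from the new one either (a 1.5-fold lower number from compound 2 to compound 4 (0.16 log units; within the scatter)). Only compound 1, with pyrrolidin-1-yl, stands apart, and a second six-membered non-aromatic ring now shows this (a 3.9-fold lower number from compound 1 to compound 4 (0.59 log units; beyond the scatter)), just as piperidin-1-yl did (a 4.4-fold lower number from compound 1 to compound 3 (0.64 log units; beyond the scatter)). Nothing measured here explains these readings.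

As far as these compounds go, whether a morpholin-4-yl or a diethylamino group at the chain end would read with compound 3 and compound 4 or with compound 1 stays open. So does the effect of a shorter or longer chain.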